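The compounds below may be only part of what the source reports. "The series", "measured", "known", "first", "only" and "open" are said of these compounds alone.

Compound 1 `COC(=O)N1CCN([C@H]2CC[C@H](Nc3ncnn4ccc([C@H](C)CC(N)=O)c34)CC2)CC1`: 58 mL/min/kg
Compound 2 `CC(=O)N1CCN([C@H]2CC[C@H](Nc3ncnn4ccc(C(C)C)c34)CC2)CC1`: 63 mL/min/kg

Of the compounds shown here, two have so far been measured in an ADME assay on the whole organism (plasma, Rattus norvegicus, strain Han Wistar) for pharmacokinetics; on this read-out lower numbers stand for slow clearance and higher numbers for fast clearance. Compound 1 gives 58 mL/min/kg, and compound 2 gives 63 mL/min/kg. Compound 2 thus carries the higher of the two numbers, but its gap to compound 1 lies within the scatter of repeated measurements, so the two stand essentially together. Among the measured compounds shown here, no step between measured compounds that differ in a single place is available here, and nothing measured shows how a change of the kind below affects this assay.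

Compound 3 `CC(=O)N1CCN([C@H]2CC[C@H](Nc3ncnn4ccc(C5CCOCC5)c34)CC2)CC1` has not yet been measured. It differs from compound 2 in one place: oxan-4-yl in place of isopropyl on an aromatic carbon. Given the absence of any measured step of this kind, the change is expected to shift this assay only modestly, by a 1.3-fold lower number from compound 2 to compound 3 (0.10 log units; within the scatter), leaning toward a lower number yet quite possibly staying within the scatter. For compound 3 in this assay the expected value is 50 mL/min/kg, with a range from 28 mL/min/kg to 90 mL/min/kg.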

Compound 3, clearance: 42 mL/min/kg
For compound 3 the middle estimate is 1.2-fold (0.08 log units) above the measured one, and the stated range covers the measured number.
By their numbers in this assay, from the lowest: compounds 3, 1 and 2 (each within the scatter of the next).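

In this assay, among the compounds shown here, oxan-4-yl in place of isopropyl on the aromatic carbon gives a 1.5-fold lower number from compound 2 to compound 3 (0.18 log units; within the scatter), the first single-place step at this position. Compound 2 and compound 3 therefore stand together, even though the entering group brings more heavy atoms, a six-membered non-aromatic ring and one hydrogen-bond acceptor. Nothing available explains this step or ties it to any property of either group.

Because the ring and its oxygen enter together, the compounds shown cannot separate their contributions, and a cyclohexyl group at the same carbon would bear directly on that question. They also leave open whether an amine, a carboxylic acid or a longer chain at this position would give a step beyond the scatter in this assay.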